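Swapping an Aromatic Ring for an Open Ether Group

The source may hold more compounds than are shown below. What is called first, only, known or untested is meant among the compounds shown, and "the series" means these compounds.

- compound 1 `O=C(NCc1cc(Cl)ccc1-n1cnnn1)[C@@H]1C[C@@H]2C[C@@H]2N1C(=O)[C@H](O)c1cccc(Cl)c1` gives 1000 nM
- compound 2 `O=C(NCc1cc(Cl)ccc1-n1cnnn1)[C@@H]1CCON1C(=O)[C@H](O)c1ccccc1` gives 1500 nM
- compound 3 `CCCC[C@@H](O)C(=O)N1N=CC[C@H]1C(=O)NCc1cc(Cl)ccc1-n1cnnn1` gives 610 nM

All three compounds were tested in a functional assay on a cell-free system (plasma, Homo sapiens), with a stated time of 3 min; on this read-out higher numbers stand for weaker inhibition and lower numbers for stronger inhibition. Compound 1 sits in the middle of the three numbers, but it lies within the usual scatter of both compound 2 and compound 3, so these values cannot be firmly ranked.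

Compound 4 `COC(C)(C)[C@@H](O)C(=O)N1[C@H](C(=O)NCc2cc(Cl)ccc2-n2cnnn2)C[C@@H]2C[C@@H]21` keeps the core of compound 1 but has 1-methoxy-1-methylethyl in place of 3-chlorophenyl on a saturated chain carbon bound to a carbonyl carbon and an oxygen on a saturated carbon.

Among the compounds with values here, no measured pair isolates this change, so the evidence is indirect. Compound 3, whose group at this carbon holds no ring, gives 610 nM on a different core. Losing the aromatic ring therefore need not cost much, and no shift beyond the scatter is expected in this assay. The expected step is a 1.1-fold lower number from compound 1 to compound 4 (0.05 log units; within the scatter). For compound 4 the estimated value is 900 nM, with an expected range from 300 nM to 3000 nM.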

Compound 4, half-maximal inhibitory concentration: 1000 nM
The estimate for compound 4 lay 1.1-fold (0.05 log units) below the measured number, within the range that was stated.
By their numbers in this assay, from the lowest: compounds 3, 1, 4 and 2 (each within the scatter of the next, the first and the last beyond it).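

Within the data shown here, on the core of compound 1, with only this one group exchanged, this assay shows no change at the digits printed from compound 1 to compound 4 (within the scatter) when 1-methoxy-1-methylethyl takes the place of 3-chlorophenyl. Among these compounds, the earlier compounds differ from one another in more than one place, so this pair is the first direct reading of the position: on this saturated chain carbon, a group with no ring and with one hydrogen-bond acceptor reads the same as the aromatic group within the scatter. No measurement shown explains why the two groups read alike.

One pair cannot show how broad this freedom at the position is. As far as these compounds go, whether an amine, a carboxylic acid or a longer chain on this same carbon would also leave the number within the scatter remains open on this core.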